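Adding a trifluoromethyl group to the phenyl ring of compound 2

A few compounds are considered here, and "the series" means these few. Any claim that something is new, unique, unknown or untested is made for them only; others in the source may bear on it.

Measured compounds:
Compound 1, `CCc1cc2ccccc2nc1-c1cc(-c2ccccc2)no1`: in a functional assay on COLO 205 cells (Homo sapiens) for inhibition, read by MTT assay, with a stated time of 24 h (a higher number here means a weaker inhibitor, a lower number a stronger inhibitor), compound 1 gives > 100000 nM, a limit of the assay and not a number.
Compound 2, `CCCc1cc2ccccc2nc1-c1cc(-c2ccccc2)no1`: in this assay compound 2 gives 48900 nM.

For the measured compounds named here, compound 2 holds the only numerical value shown here; the other value, that of compound 1, sits at the limit of > 100000 nM in this assay, at which 1 of the 2 values shown sits. Going by the values given here, the one measured step, an at least 2.0-fold lower number from compound 1 to compound 2 (0.31 log units; beyond the scatter), concerns the saturated chain on the shared core and says nothing about the phenyl ring.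

Compound 3, `CCCc1cc2ccccc2nc1-c1cc(-c2ccc(C(F)(F)F)cc2)no1`, differs from compound 2 by trifluoromethyl in place of hydrogen on an aromatic carbon. Among the compounds with values here, no measured step touches this part of the molecule, so the measured data give no direct guide to the size or direction of the change. The expected step from compound 2 to compound 3 in this assay is therefore a 1.6-fold lower number from compound 2 to compound 3 (0.21 log units; within the scatter), a step that stays close to the scatter. Compound 3 is accordingly estimated at 30000 nM, with a range from 6000 nM to 150000 nM.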

Compound 3, half-maximal inhibitory concentration: 42200 nM
Estimate against measurement, compound 3: 1.4-fold (0.15 log units) below; measured number inside the range.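

In this assay the phenyl ring now has a measured step of its own (a 1.2-fold lower number from compound 2 to compound 3 (0.06 log units; within the scatter)). Trifluoromethyl brings 4 heavy atoms to an aromatic carbon, para to a large group, where only a hydrogen stood before, and yet the number for compound 3 cannot be told apart from that of compound 2, whereas the one earlier step, on the saturated chain, lay beyond the scatter. So this position accepts this one substitution without a change that can be read in this assay, although nothing shown explains why the number stays where it does.

Trifluoromethyl is the only group other than hydrogen shown at this place, so it remains open whether an amine or a carboxylic acid on the same aromatic carbon would move the number beyond the scatter. For the compounds shown here, it also remains open whether a longer chain on the shared core would give a lower number still, which matters more here, since the only step beyond the scatter so far came from the chain.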